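Swapping the Chain on the Ring Nitrogen of Compound 3

The compounds below may be only part of what the source reports. "The series", "measured", "known", "first", "only" and "open" are said of these compounds alone.

Of the compounds shown here, three sharing one core have been measured in an in vitro ADME assay on microsomes from liver (Homo sapiens) for metabolic stability, tested at 5 uM; a lower number here means that the compound disappears faster, a higher number that the compound lasts longer. Compound 1 `CC(C)CCn1nc(-c2ccn(C)c2)c(O)c(C2=NS(=O)(=O)c3cc(NS(C)(=O)=O)ccc3N2)c1=O` gives 0.633 h. Compound 2 `CC(C)CCn1nc(-c2ccccc2)c(O)c(C2=NS(=O)(=O)c3cc(NS(C)(=O)=O)ccc3N2)c1=O` gives 0.633 h, and the step of no change at the digits printed from compound 1 to compound 2 (within the scatter) stays within the scatter. For compound 3 `CCCC(C)n1nc(-c2cccs2)c(O)c(C2=NS(=O)(=O)c3cc(NS(C)(=O)=O)ccc3N2)c1=O` only a limit is known: > 1 h, so it sits at the limit of > 1 h in this assay, at which 1 of the 3 values shown sits, rather than at a number.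

Compound 4 `CS(=O)(=O)Nc1ccc2c(c1)S(=O)(=O)N=C(c1c(O)c(-c3cccs3)nn(Cc3ccccn3)c1=O)N2` differs from compound 3 in one place: (pyridin-2-yl)methyl in place of 1-methylbutyl on an aromatic nitrogen. For the measured compounds named here, the only measured step, from compound 1 to compound 2, changes a group on an aromatic carbon, not the chain on the ring nitrogen, so it tells little about this change. Going by the values given here, no measured step speaks to the size or direction of the present one, and the starting point is itself only a limit.

The step expected in this assay is therefore a number no higher from compound 3 to compound 4 (the limit leaves the size open), with no direction favoured beyond the scatter. Compound 4 is estimated at 1 h, between 0.45 h and 2.2 h.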

Compound 4, half-life: > 1 h
Compound 4 ended at the assay's limit; the forecaster's own chance of this, stated with the estimate: 45%; the middle value lies on the limit itself.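

In this assay compound 3 and compound 4 both rest at a limit rather than a number, so no step can be read between them: the limit of > 1 h in this assay, at which 2 of the 4 values shown sit.

Going by these compounds, how long each compound lasts beyond that limit stays open, and so does whether 1-methylbutyl or (pyridin-2-yl)methyl gives the longer half-life.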